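The source may hold more compounds than are shown below. What is called first, only, known or untested is meant among the compounds shown, and "the series" means these compounds.

Compound 1 `COc1cc([C@](O)(CCN(C)C)[C@@H](c2cc3cc(C#N)ccc3nc2OC)c2cccc(OC)c2F)cc(SC)n1` gives 16 uL/min in an ADME assay on microsomes from liver (Homo sapiens) for metabolic stability; on this read-out higher numbers stand for fast clearance and lower numbers for slow clearance.
Compound 2 `COc1cccc([C@H](c2cc3cc(C#N)ccc3nc2OC)[C@@](O)(CCN(C)C)c2cc(SC)nc(SC)c2)c1F` gives 15 uL/min in this assay.
Compound 3 `CCSc1cc([C@](O)(CCN(C)C)[C@@H](c2cc3cc(Br)ccc3nc2OC)c2cccc(OC)c2F)cc(SCC)n1` gives 4.9 uL/min in this assay.

Compound 3 has the lowest of the three numbers in this assay; compound 2 is the nearest and compound 1 the furthest, and both stand beyond the scatter above it. Compound 4 `CCSc1cc([C@](O)(CCN(C)C)[C@@H](c2cc3cc(C#N)ccc3nc2OC)c2cccc(OC)c2F)cc(SCC)n1` differs from compound 3 by cyano in place of bromo on an aromatic carbon. Within the data shown here, the only measured step, a 1.1-fold lower number from compound 1 to compound 2 (0.03 log units; within the scatter), concerns a different change and does not bear on this one. Among the measured compounds shown here, no measured pair isolates cyano against bromo: compound 1 and compound 2 carry cyano but also differ from compound 3 in their sulfanyl groups. With nothing to go on, the number for compound 4 is expected to stay near that of compound 3, a 1.1-fold lower number from compound 3 to compound 4 (0.04 log units; within the scatter), with no step beyond the scatter. The estimate for compound 4 in this assay is 4.5 uL/min, between 2 uL/min and 10 uL/min.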

Compound 4, intrinsic clearance in a liver preparation (reported as CLH), per the amount of preparation that the assay uses: 17 uL/min
Estimate against measurement, compound 4: 3.8-fold (0.58 log units) below; measured number above the stated range.
By their numbers in this assay, from the lowest: compound 3; then compounds 2, 1 and 4 (each within the scatter of the next).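

Among these compounds, on an aromatic carbon of the six-membered aromatic ring of carbon only, cyano in place of bromo is the first change here to move the number in this assay beyond the scatter, a 3.5-fold higher number from compound 3 to compound 4 (0.54 log units; beyond the scatter). With cyano at this place, the group of 12 heavy atoms in place of either group of 10 heavy atoms gives a 1.1-fold higher number from compound 2 to compound 4 (0.05 log units; within the scatter) and a 1.1-fold higher number from compound 1 to compound 4 (0.03 log units; within the scatter), so the low number of compound 3 goes with bromo in these compounds. Nothing at hand explains this step.

From the compounds shown here alone, whether bromo gives as low a number alongside either group of 10 heavy atoms remains open. So does how chloro, methyl or an amine at this place would compare.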